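The source may hold more compounds than are shown below. What is called first, only, known or untested is meant among the compounds shown, and "the series" means these compounds.

Working notes on the series, read in a functional assay (Homo sapiens) for inhibition; a higher number here means a weaker inhibitor, a lower number a stronger inhibitor. Compound 1 (`CCCc1cc(/C=C/C(=O)c2ccc(O)cc2)c(OC)cc1O`) gives 41000 nM, compound 2 (`COc1cc(/C=C/C(=O)c2ccccc2[N+](=O)[O-])cc(OC)c1`) gives 3700 nM, and compound 3 (`C=CCOc1ccc(C(=O)/C=C/c2cccc(OC)c2OC)cc1`) gives 96000 nM. Compound 3 thus has the highest number of the three and is the weakest inhibitor, beyond the scatter against both others. Compound 4 (`COc1cccc(/C=C/C(=O)c2ccc(O)cc2)c1OC`) puts hydrogen in place of allyl on an oxygen on an aromatic ring, allyloxy to hydroxy: hydrogen in place of allyl on an oxygen on an aromatic ring. Among the measured compounds shown here, no measured pair isolates this change, so the guide is thin. Compound 1, at 41000 nM, also carries a hydroxy group. A modest move to a lower number is expected in this assay, and the estimated step of a 2.4-fold lower number from compound 3 to compound 4 (0.38 log units; beyond the scatter) may not clear the scatter by much. For compound 4 the estimate is 40000 nM, with an expected range of 12000 nM to 110000 nM.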

Compound 4, half-maximal inhibitory concentration: 70000 nM
Compound 4: the middle estimate sits 1.8-fold (0.24 log units) below what was measured; low and high end bracket the measured number.
By their numbers in this assay, from the lowest: compound 2; then compounds 1, 4 and 3 (each within the scatter of the next, the first and the last beyond it).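

Hydrogen in place of allyl on an oxygen on an aromatic ring gives a 1.4-fold lower number from compound 3 to compound 4 (0.14 log units; within the scatter) and is the first step in the series that isolates a single change. On this evidence, allyloxy and hydroxy at this place cannot be told apart, as compound 3 and compound 4 stand within the scatter of each other. No supporting data bear on this result. As far as these compounds go, whether a longer chain or an amine-bearing chain on this oxygen would read differently stays open, as does whether this step holds with other substituents on the shared core.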